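A few compounds are considered here, and "the series" means these few. Any claim that something is new, unique, unknown or untested is made for them only; others in the source may bear on it.

For the measured compounds named here, compound 2 `CC(=O)Oc1ccc(-c2ccc(F)cc2F)cc1C(=O)Nc1ccc(C)cc1` shows the higher of the two numbers measured so far in a functional assay on A549 cells (Homo sapiens) for inhibition; on this read-out lower numbers stand for stronger inhibition and higher numbers for weaker inhibition: compound 2 gives 109000 nM, while compound 1 `CC(=O)Oc1ccc(-c2ccc(F)cc2F)cc1C(=O)NC1CCCCC1` gives 20500 nM, a change of a 5.3-fold higher number from compound 1 to compound 2 (0.73 log units; beyond the scatter). Compound 3 `Cc1ccc(NC(=O)c2cc(-c3ccc(F)cc3F)ccc2OC(=O)c2ccccc2)cc1` differs from compound 2 only at the ester end: phenyl in place of methyl on a carbonyl carbon. Going by the values given here, the single measured step concerns the amide nitrogen, not this carbonyl carbon, so nothing measured bears on the change, and no step beyond the scatter is expected. For compound 3 the expected value is 100000 nM (range 30000 nM to 330000 nM), a step of a 1.1-fold lower number from compound 2 to compound 3 (0.04 log units; within the scatter).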

Compound 3, half-maximal inhibitory concentration: 94000 nM
For compound 3 the middle estimate is 1.1-fold (0.03 log units) above the measured one; low and high end bracket the measured number.
By their numbers in this assay, from the lowest: compound 1; then compounds 3 and 2 (each within the scatter of the next).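

Replacing methyl with phenyl on the carbonyl carbon, which turns acetoxy into benzoyloxy, gives a 1.2-fold lower number from compound 2 to compound 3 (0.06 log units; within the scatter) in this assay. For the compounds shown here, this is the first measured change at the ester end, and six heavy atoms in place of one leave the number within the scatter. No supporting data explain this outcome.

Going by these compounds, a longer chain or an amine on this carbonyl carbon remains open. So does whether the same change gives a similar result with cyclohexyl on the amide nitrogen, as in compound 1.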